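The source may report more compounds than this note shows. Statements on the series, on what has been measured and on what is new or still open speak of the compounds shown alone.

Working notes on the series in a functional assay on KB cells (Homo sapiens) for cytotoxicity, read by MTT assay, with a stated time of 72 h; on this read-out higher numbers stand for an effect only at larger amounts of compound and lower numbers for an effect already at smaller amounts.

Compound 1 `COc1ccc(Nc2cc(-c3ccccc3)oc(=O)c2)cc1` gives 0.16 uM. Compound 2 `COc1ccc(Nc2cc(C)oc(=O)c2)cc1` reaches only the limit of the assay, > 30 uM, and no number is known for it. Compound 3 `Cc1ccc(Nc2cc(-c3ccccc3)oc(=O)c2)cc1` gives 0.064 uM and so holds the lowest of the two numbers; its nearest neighbour is compound 1, and the step is a 2.5-fold lower number from compound 1 to compound 3 (0.40 log units; beyond the scatter), a methyl in place of methoxy on an aromatic carbon. The other measured step, an at least 180-fold higher number from compound 1 to compound 2 (2.27 log units; beyond the scatter), shows that exchanging the phenyl on an aromatic carbon for methyl drives the value to the limit (the limit of > 30 uM in this assay, at which 1 of the 3 values shown sits).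

Compound 4 `O=c1cc(NC2CC2)cc(-c2ccccc2)o1` is not yet measured. It differs from compound 3 as cyclopropyl in place of 4-methylphenyl on a nitrogen on an aromatic ring: a six-membered aromatic ring of carbon only leaves and a three-membered non-aromatic ring of carbon only enters, both without donors or acceptors. Among the measured compounds shown here, no measured step touches this nitrogen, so the expectation rests on the general sensitivity seen in an at least 180-fold higher number from compound 1 to compound 2 (2.27 log units; beyond the scatter) when an aromatic ring is lost. A substantial weakening is expected, a 78-fold higher number from compound 3 to compound 4 (1.89 log units; beyond the scatter), short of the limit. The estimated value for compound 4 is 5 uM, with a range from 0.5 uM to 30 uM.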

Compound 4, concentration for half-maximal effect: > 30 uM
Compound 4: only a limit was reported; the forecaster's own chance of this, stated with the estimate: 25%; middle value at least 6.0-fold (0.77 log units) from the limit.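

Among the compounds shown here, on this nitrogen the group matters far more than the earlier compounds could show: cyclopropyl in place of 4-methylphenyl gives an at least 460-fold higher number from compound 3 to compound 4 (2.67 log units; beyond the scatter) in this assay. For the compounds shown here, the only earlier change on this side of the molecule, a 2.5-fold lower number from compound 1 to compound 3 (0.40 log units; beyond the scatter), altered a substituent and kept the six-membered aromatic ring, so the loss of that ring here is a new and much larger kind of step. For compound 4, > 30 uM is a limit and not a number, which makes it the second such result in the series: the limit of > 30 uM in this assay, at which 2 of the 4 values shown sit.

The compounds shown leave open whether the six-membered aromatic ring itself is needed on this nitrogen, or whether a non-aromatic ring such as cyclohexyl, or a benzyl, would also keep a low number. Also open, from the compounds shown here alone, is how far the 4-methylphenyl ring tolerates other groups in place of the methyl, such as an amine or a carboxylic acid.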